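From a Hexyl Chain to a Cyclopentyl Ring

This account rests on a few compounds, and the source may have more. Where it says the series, first, only, none or still open, it means among the compounds named here.

Of the compounds shown here, three sharing one core have been tested in an in vitro functional assay on cells for antagonist activity at metabotropic glutamate receptor 1 (Rattus norvegicus), read by inositol phosphate accumulation; on this read-out higher numbers stand for weaker inhibition and lower numbers for stronger inhibition. Compound 1 `CC1(C)CC(=O)c2cc(C#N)c(N3CCN(c4ccc(F)cc4)CC3)nc2C1` gives 160 nM. Compound 2 `CN(Cc1ccccc1)c1nc2c(cc1C#N)C(=O)CC(C)(C)C2` gives 5300 nM. Compound 3 `CCCCCCNc1nc2c(cc1C#N)C(=O)CC(C)(C)C2` gives 2600 nM, which places it second highest of the three numbers: its nearest neighbour is compound 2, whose number is higher by a margin beyond the usual scatter, and its furthest is compound 1, whose number is far lower.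

Compound 4 `CC1(C)CC(=O)c2cc(C#N)c(NC3CCCC3)nc2C1` has not yet been measured. It differs from compound 3 in one place only: cyclopentyl in place of hexyl on a nitrogen on an aromatic ring. Within the data shown here, since no measured pair shows this kind of exchange, its effect is not known from the data at hand, and the other two compounds carry quite different groups on that nitrogen.

In this assay the step of a 1.7-fold lower number from compound 3 to compound 4 (0.24 log units; within the scatter) is expected to be modest, likely toward a somewhat lower number, but a result within the scatter of compound 3 would not be surprising. Compound 4 is therefore estimated at 1500 nM, with a range from 400 nM to 6000 nM.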

Compound 4, half-maximal inhibitory concentration: 78 nM
Compound 4: the middle estimate sits 19-fold (1.28 log units) above what was measured, outside the stated range (below it).
By their numbers in this assay, from the lowest: compound 4; then compound 1; then compound 3; then compound 2.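

In this assay, cyclopentyl in place of hexyl on a nitrogen on an aromatic ring gives a 33-fold lower number from compound 3 to compound 4 (1.52 log units; beyond the scatter). This shows that the position is highly sensitive to which carbon group it carries, even though neither group has a hydrogen-bond donor or acceptor and the change is only from a chain of 6 carbon atoms to a ring of 5. Nothing measured here explains why the ring gives so much stronger inhibition than the chain.

One pair cannot separate the effect of having a ring from the effect of the carbon count, and a straight pentyl chain would bear directly on that question. On these data alone, it also remains open how ring size matters, as a cyclobutyl or cyclohexyl group on the same nitrogen would show.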